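Stilbenoid core: formyl replaced by fluorophenylethenyl

The compounds below may be only part of what the source reports. "The series", "measured", "known", "first", "only" and "open" are said of these compounds alone.

Compound 1 `C=C[C@@](C)(/C=C/c1ccc(OS(=O)(=O)C(F)(F)F)cc1)CCC=C(C)C` — > 43400 nM
Compound 2 `C=C[C@@](C)(/C=C/c1ccc(O)c(C=O)c1)CCC=C(C)C` — 11200 nM

Of the compounds shown here, two have been measured in a functional assay on NALM-6 cells (Homo sapiens) for cytotoxicity, with a stated time of 72 h; a higher number here means that more compound is needed for the effect, a lower number that less compound is needed. Compound 1 reaches only the limit of the assay, > 43400 nM, and gives no number. For the measured compounds named here, compound 2 is the only compound with a measured number, 11200 nM; it thus stands at the sole fixed point of the series. Compound 1 stands at the limit of > 43400 nM in this assay, at which 1 of the 2 values shown sits.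

Compound 3 `C=C[C@@](C)(/C=C/c1ccc(O)c(/C=C/c2ccc(F)cc2)c1)CCC=C(C)C` follows from compound 2 by a change at a single place on the shared core: 2-(4-fluorophenyl)ethenyl in place of formyl on an aromatic carbon. The entering group sits ortho to a hydroxy group and meta to a large group, where the formyl stood before.

Going by the values given here, no measured step between two compounds is available, so the size of the change from compound 2 to compound 3 in this assay cannot be read from a precedent. Given that compound 2 gives 11200 nM, a moderate step towards a lower value is expected, a 2.8-fold lower number from compound 2 to compound 3 (0.45 log units; beyond the scatter), beyond the usual scatter but not far beyond it. Compound 3 is therefore estimated at 4000 nM, within a range from 1000 nM to 20000 nM.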

Compound 3, half-maximal effective concentration: > 43400 nM
Compound 3 ended at the assay's limit; the forecaster's own chance of this, stated with the estimate: 15%; middle value at least 10-fold (1.03 log units) from the limit.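

In this assay, this place on an aromatic carbon, ortho to a hydroxy group and meta to a large group, turns out not to tolerate the exchange of formyl for 2-(4-fluorophenyl)ethenyl, which gives an at least 3.8-fold higher number from compound 2 to compound 3 (0.58 log units; beyond the scatter). Compound 3 gives > 43400 nM, a limit of the assay and not a number, so the step fixes only its smallest size, not its true size. Compound 2 therefore remains the only compound with a measured number, and this single change is enough to move the shared core out of the measurable range: the limit of > 43400 nM in this assay, at which 2 of the 3 values shown sit.

The compounds shown leave open whether a smaller group at this place, such as a methyl, a hydroxymethyl or an amine, would keep a measurable value, and so how much of the number of compound 2 depends on the formyl itself. Also open, from the compounds shown here alone, is how much of the step belongs to the fluorine and how much to the ethenyl-linked ring, which a plain 2-phenylethenyl group at this place could separate.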